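Trimming the Ester to an Aldehyde on the Aryl Ring

The source may hold more compounds than are shown below. What is called first, only, known or untested is meant among the compounds shown, and "the series" means these compounds.

Of the compounds shown here, two built on a shared core have been measured in a functional assay on HCT-116 cells (Homo sapiens) for antiproliferative activity, read by MTT assay, with a stated time of 48 h (on this read-out lower numbers stand for stronger inhibition and higher numbers for weaker inhibition), so far. Compound 1 `COc1ccc(-n2cc(COc3ccc(/C=C/C(C)=O)cc3OC)nn2)cc1` gives 21300 nM in this assay. For the measured compounds named here, compound 2 `CCOC(=O)c1ccc(-n2cc(COc3ccc(/C=C/C(C)=O)cc3OC)nn2)cc1` gives 78900 nM in this assay, which is the higher of the two numbers, and the only measured step, a 3.7-fold higher number from compound 1 to compound 2 (0.57 log units; beyond the scatter), separates it from compound 1.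

Compound 3 `COc1cc(/C=C/C(C)=O)ccc1OCc1cn(-c2ccc(C=O)cc2)nn1` is the next member of the series. It differs from compound 2 at the group on the carbonyl carbon whose other neighbour is an aromatic carbon: hydrogen in place of ethoxy on a carbonyl carbon, so that the ethoxycarbonyl of compound 2 becomes a formyl in compound 3.

Going by the values given here, only the step from compound 1 to compound 2 touches this part of the molecule, and it showed that altering the group on this aromatic carbon moves the number modestly. Cutting the ester back to an aldehyde is a smaller change than the earlier exchange, so a modest step downward is expected, a 2.0-fold lower number from compound 2 to compound 3 (0.30 log units; within the scatter), with compound 3 expected to give about 40000 nM in this assay, within a range from 15000 nM to 110000 nM.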

Compound 3, half-maximal inhibitory concentration: 76200 nM
For compound 3 the middle estimate is 1.9-fold (0.28 log units) below the measured one; the measured number falls inside the stated range.
By their numbers in this assay, from the lowest: compound 1; then compounds 3 and 2 (each within the scatter of the next).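

In this assay the group on the carbonyl carbon turns out to matter little: removing the ethoxy, so that ethoxycarbonyl becomes formyl, gives a 1.0-fold lower number from compound 2 to compound 3 (0.02 log units; within the scatter) and leaves compounds 2 and 3 indistinguishable. The comparison with methoxy on the aromatic carbon now has a second example, since formyl in place of methoxy gives a 3.6-fold higher number from compound 1 to compound 3 (0.55 log units; beyond the scatter) and this step is close in size to the one seen with ethoxycarbonyl, so both carbonyl-bearing groups stand apart from the methoxy of compound 1, which has the lowest number of the three. No measurement at hand explains why the number changes with methoxy but not with the ethoxy on the carbonyl carbon.

Going by these compounds, it remains open whether a carboxylic acid or an amide on this aromatic carbon would group with compounds 2 and 3 or with compound 1. On these data alone, it is also open whether a group without a carbonyl, such as an amine or a longer alkoxy chain, would match the number of compound 1 or go past it.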